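The compounds below may be only part of what the source reports. "The series", "measured", "known", "first", "only" and "open" are said of these compounds alone.

Of the compounds shown here, three have so far been measured in a functional assay for antagonist activity at thromboxane A2 receptor (Rattus norvegicus); on this read-out lower numbers stand for tighter binding and higher numbers for weaker binding. Compound 1 `CC(=O)NCc1ccc(-c2ccc(COC3CC[C@H](N4CCCCCC4)[C@H]3OC/C=C\CCC(=O)O)cc2)cc1` gives 20 nM in this assay, the second highest of the three numbers. Compound 3 `O=C(O)CC/C=C\CO[C@@H]1C(OCc2ccc(-c3ccccc3)cc2)CC[C@@H]1N1CCCCC1` gives 15.9 nM, which lies within the usual scatter of the value for compound 1, so the two cannot be told apart. Compound 2 `CS(=O)(=O)Nc1ccccc1-c1ccc(CO[C@H]2CC[C@H](N3CCCCCC3)[C@H]2OC/C=C\CCC(=O)O)cc1` gives 63.1 nM, a number beyond the scatter above compound 1, so compound 2 binds more weakly than compound 1.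

The next compound, compound 4 `O=C(O)CC/C=C\CO[C@H]1C(OCc2ccc(-c3ccccc3O)cc2)CC[C@@H]1N1CCCCCC1`, has not yet been measured. It differs from compound 1 in one place: 2-hydroxyphenyl in place of 4-(acetamidomethyl)phenyl on an aromatic carbon. Among the compounds with values here, no pair of measured compounds differs in exactly this way, so there is no directly comparable step to lean on; the values of compound 3 and compound 2 only show that changes on this part of the molecule can leave the number within the scatter of compound 1 or raise it beyond the scatter.

The step from compound 1 to compound 4 is expected to be modest, a 1.3-fold higher number from compound 1 to compound 4 (0.10 log units; within the scatter), in the direction of a slightly higher number, and it may well remain within the scatter. Compound 4 is therefore estimated at 25 nM, with a range from 8 nM to 80 nM.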

Compound 4, dissociation constant: 20 nM
Beside the measured number, compound 4's estimate is 1.3-fold (0.10 log units) above it, and the stated range covers the measured number.
By their numbers in this assay, from the lowest: compounds 3, 1 and 4 (each within the scatter of the next); then compound 2.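

In this assay, within the data shown here, replacing 4-(acetamidomethyl)phenyl with 2-hydroxyphenyl gives no change at the digits printed from compound 1 to compound 4 (within the scatter), the first change at a single place that can be read directly in this set. At this aromatic carbon, para to a large group, the substituent can therefore shrink from 11 heavy atoms to 7 and lose the double bond outside aromatic rings with no detectable change in the number, while the six-membered aromatic ring and the count of 1 hydrogen-bond donor and 1 hydrogen-bond acceptor stay the same. No measurement available here accounts for this result.

Because the donor and acceptor counts match in the two groups, the compounds shown leave open whether the number would hold with other groups at this place, such as 4-(aminomethyl)phenyl, which carries a basic amine, or 2-methoxyphenyl, which replaces the hydroxyl hydrogen with a methyl group. A single step also leaves open whether the same exchange would give the same result on a core other than that of compound 1.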